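The source may hold more compounds than are shown below. What is called first, only, known or untested is meant among the compounds shown, and "the series" means these compounds.

In an ADME assay (liver) for metabolic stability, with Liver microsome (Rattus norvegicus) as the target, read by LC-MS, using microsomes and NADPH, with stated times of 5 min and 60 min, tested at 4 uM (a lower number here means that less of the compound is left, a higher number that more of the compound is left), compound 1 (`Cc1cc(C(=O)O)ccc1OCCCCOc1ccc(C(=O)CC(C)C)c(O)c1C`) gives 41% and stands level with compound 3 (`COc1cc(C(=O)O)ccc1OCCCCOc1ccc(C(=O)CC(C)C)c(O)c1C`), which gives 43% within the scatter of it. Compound 2 (`Cc1c(OCCCCOc2ccc(C(=O)O)cc2Cl)ccc(C(=O)CC2CCCC2)c1O`) gives 21% and lies clearly lower than both. Compound 4 (`Cc1c(OCCCCOc2ccc(C(=O)O)cc2F)ccc(C(=O)CC(C)C)c1O`) has not been measured yet, and its change from compound 1 is fluoro in place of methyl on an aromatic carbon. Among the measured compounds shown here, the one measured step that replaces this same methyl, with methoxy, is a number 2 percentage points higher from compound 1 to compound 3 (within the scatter) and stays small. For the measured compounds named here, no measured step shows fluoro in place of methyl, so no change beyond the scatter is expected in this assay and the expected step is a number 1 percentage points lower from compound 1 to compound 4 (within the scatter) for this swap. Compound 4 is estimated at 40% with an expected range from 25% to 55% in this measurement.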

Compound 4, percent of the compound remaining: 57%
The estimate for compound 4 lay 17 percentage points below the measured number; measured number above the stated range.
By their numbers in this assay, from the lowest: compound 2; then compounds 1 and 3 (each within the scatter of the next); then compound 4.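

In this assay this aromatic carbon, meta to a carboxy group, turns out to respond to what sits on it: fluoro in place of methyl gives a number 16 percentage points higher from compound 1 to compound 4 (beyond the scatter) and fluoro in place of methoxy gives a number 14 percentage points higher from compound 3 to compound 4 (beyond the scatter), whereas methoxy in place of methyl gave only a number 2 percentage points higher from compound 1 to compound 3 (within the scatter). The small methoxy step therefore did not speak for every group here. No measurement shown explains the gain with fluoro. Still open, on these data alone, is how a nitrile or an amine on this carbon would compare with fluoro.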